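Expected activity of compound 4 from a repeated change

The source may hold more compounds than are shown below. What is called first, only, known or untested is meant among the compounds shown, and "the series" means these compounds.

Measured compounds:
compound 1 `CCCSc1nnc(Cc2ccc(Cl)cc2Oc2ccccc2Cl)[nH]1`: 125%
compound 2 `Clc1ccc(Cc2nnc(SCc3ccccc3)[nH]2)c(Oc2ccccc2Cl)c1`: 122%
compound 3 `CCCSc1nnc(Cc2ccc(Cl)cc2Oc2ccccc2F)[nH]1`: 127%

In a functional assay on the whole organism (strain NMRI) with Mus musculus as the target, with a stated time of 60 min, at a dose of 10 mg/kg by the intraperitoneal route (a higher number here means a stronger effect of the compound at the dose given, a lower number a weaker effect), compound 1 gives 125%. Compound 2 differs from compound 1 by phenyl in place of ethyl on a saturated chain carbon bound to a sulfur, and the step is a number 3 percentage points lower from compound 1 to compound 2 (within the scatter). Compound 3 differs from compound 1 by fluoro in place of chloro on an aromatic carbon, with a step of a number 2 percentage points higher from compound 1 to compound 3 (within the scatter). The three values lie within the scatter of one another.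

Compound 4 `Fc1ccccc1Oc1cc(Cl)ccc1Cc1nnc(SCc2ccccc2)[nH]1` has not yet been measured. It differs from compound 3 by phenyl in place of ethyl on a saturated chain carbon bound to a sulfur, the same change at the same place as that from compound 1 to compound 2. Because that change gave a number 3 percentage points lower from compound 1 to compound 2 (within the scatter), a step of similar size is expected in this assay, namely a number 3 percentage points lower from compound 3 to compound 4 (within the scatter). Compound 4 is therefore estimated at 124%, expected to fall between 112% and 136%.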

Compound 4, a percentage reported as activity, at one dose (the size of the read-out at that dose, not a potency): 169%
Estimate against measurement, compound 4: 45 percentage points below, and the stated range ends below it.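

In this assay, phenyl in place of ethyl on a saturated chain carbon bound to a sulfur did not carry over from one core to the other; on the fluoro core the step was a number 42 percentage points higher from compound 3 to compound 4 (beyond the scatter), which does not match the earlier step: the same change on two cores in this assay, a number 3 percentage points lower (within the scatter) from compound 1 to compound 2 and a number 42 percentage points higher (beyond the scatter) from compound 3 to compound 4, 45 percentage points apart, beyond the scatter of two such steps. Fluoro in place of chloro on an aromatic carbon likewise did not carry over, with a step of a number 47 percentage points higher from compound 2 to compound 4 (beyond the scatter), which does not match its earlier step: the same change on two cores in this assay, a number 2 percentage points higher (within the scatter) from compound 1 to compound 3 and a number 47 percentage points higher (beyond the scatter) from compound 2 to compound 4, 45 percentage points apart, beyond the scatter of two such steps. The two changes therefore do not add up across these compounds, but both large steps rest on compound 4 alone, and the data do not show why the combination stands apart.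

The compounds shown leave open whether this holds for other groups on the sulfur, such as a longer chain or a chain carrying an amine. They also leave open how a methoxy group in place of the fluoro would behave alongside the benzylsulfanyl group.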